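The source may hold more compounds than are shown below. What is called first, only, known or untested is meant among the compounds shown, and "the series" means these compounds.

Working notes on the series, read in a functional assay on KB403 cells (Homo sapiens) for cytotoxicity, read by MTT assay, with stated times of 6 h and 48 h; a lower number here means a stronger inhibitor, a higher number a weaker inhibitor. Compound 1 (`COc1ccc(C(=O)/C=C/c2cc(Br)c(Br)n2C)c(OC)c1`) gives only a limit, >= 100000 nM, and no number. Compound 2 (`Cn1c(/C=C/C(=O)c2ccc(Cl)cc2Cl)cc(Br)c1Br`) also gives only a limit, >= 100000 nM. Compound 3 (`Cn1c(/C=C/C(=O)c2cc(O)ccc2O)cc(Br)c1Br`) likewise gives only a limit, >= 100000 nM. Compound 1 therefore has no numerical rank in the series, where the data so far stand at the limit of >= 100000 nM in this assay, at which 3 of the 3 values shown sit. Among the compounds with values here, no measured pair differing in one place is available, so the size of a single structural change remains unknown here.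

Compound 4 (`COc1ccc(C(=O)/C=C/c2cc(Br)c(Br)[nH]2)c(OC)c1`) departs from the core of compound 1 at one place: hydrogen in place of methyl on an aromatic nitrogen, with hydrogen in place of methyl on an aromatic nitrogen. The expectation rests only on this change and on the limit reached by compound 1 at >= 100000 nM. A small shift toward stronger inhibition is expected, estimated as an at least 1.4-fold lower number from compound 1 to compound 4 (0.15 log units; that floor lies within the scatter), and another result reported only as a limit would be no surprise. The expected value for compound 4 is 70000 nM, with an estimated range from 20000 nM to 150000 nM.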

Compound 4, half-maximal inhibitory concentration: >= 100000 nM
Compound 4 was reported as a limit; the forecaster's own chance of this, stated with the estimate: 55%; middle value at least 1.4-fold (0.15 log units) away from the limit.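

Compound 1 and compound 4 both end at a limit, so the step of hydrogen in place of methyl on an aromatic nitrogen cannot be read: the limit of >= 100000 nM in this assay, at which 4 of the 4 values shown sit.

The compounds shown leave open how far any single structural change moves the read-out; none of them gives a number.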